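The source may hold more compounds than are shown below. What is called first, only, known or untested is meant among the compounds shown, and "the series" means these compounds.

Compound 2 `O=C(OCCc1c(-c2ccccc2Cl)c2cc(Cl)ccc2[nH]c1=O)c1cccnc1` carries a pyridin-3-yl group on the carbonyl carbon of its ester, and in an ADME assay on HepG2 2.2.15 cells (Homo sapiens) for cytotoxicity (on this read-out lower numbers stand for higher toxicity in this test and higher numbers for lower toxicity in this test), compound 2 gives 170000 nM. Among the two compounds measured in this assay, compound 2 stands at the highest number. Within the data shown here, its only neighbour is compound 1 `CC(C)C(=O)OCCc1c(-c2ccccc2Cl)c2cc(Cl)ccc2[nH]c1=O`, which in this assay gives 62000 nM. The step between them is a 2.7-fold higher number from compound 1 to compound 2 (0.44 log units; beyond the scatter). Compound 3 `C/C=C(\C)C(=O)OCCc1c(-c2ccccc2Cl)c2cc(Cl)ccc2[nH]c1=O` is the next compound to be measured; it differs from compound 2 by 1-methylprop-1-en-1-yl in place of pyridin-3-yl on a carbonyl carbon.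

Among the measured compounds shown here, the only measured step that bears on this change is the one from compound 1 to compound 2, where a pyridin-3-yl group replaced an isopropyl group on the same carbonyl carbon and the number rose modestly. Compound 3 removes that pyridin-3-yl group again and puts in its place a 1-methylprop-1-en-1-yl group, a four-carbon chain without a ring. Since compound 1, which also carries a ring-free group at that position, gives 62000 nM, the number for compound 3 is expected to fall back toward that of compound 1, by a 2.3-fold lower number from compound 2 to compound 3 (0.36 log units; beyond the scatter). Compound 3 is therefore estimated at 75000 nM, in a range from 30000 nM to 190000 nM.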

Compound 3, half-maximal cytotoxic concentration: 350000 nM
Compound 3: middle estimate off by 4.7-fold (0.67 log units), on the low side, outside the stated range (above it).
By their numbers in this assay, from the lowest: compound 1; then compound 2; then compound 3.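

In this assay, putting the 1-methylprop-1-en-1-yl group on the carbonyl carbon in place of pyridin-3-yl gives a 2.1-fold higher number from compound 2 to compound 3 (0.31 log units; beyond the scatter) and takes the top place from the ring-bearing ester. Against the other ring-free group, the same 1-methylprop-1-en-1-yl group gives a 5.6-fold higher number from compound 1 to compound 3 (0.75 log units; beyond the scatter) in place of isopropyl, the largest of the steps so far, so ring-free groups now stand on both sides of pyridin-3-yl and the presence of a ring at this position does not order the three compounds. No measurement at hand accounts for this order of the three esters.

The compounds shown leave open whether the higher number goes with the double bond of the 1-methylprop-1-en-1-yl group or with its chain, a question that a saturated butyl group on the same carbonyl carbon would address. Also open, as far as these compounds go, is how an amine or a carboxylic acid at this position would read, and whether the order of these three groups holds on any other core.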